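Adding 5-methylthiophen-2-yl to compound 2

This account rests on a few compounds, and the source may have more. Where it says the series, first, only, none or still open, it means among the compounds named here.

- compound 1 `CCOc1cc(NC(=O)CCCCCCC(=O)Nc2cc(-c3ccccc3)ccc2N)cc2c1OCC([N+](=O)[O-])=C2`: 10700 nM
- compound 2 `CCOc1cc(NC(=O)CCCCCCC(=O)Nc2ccccc2N)cc2c1OCC([N+](=O)[O-])=C2`: 8630 nM

In a functional assay on PC-3 cells (Homo sapiens) for antiproliferative activity, read by MTT assay, with a stated time of 48 h (a lower number here means a stronger inhibitor of growth, a higher number a weaker inhibitor of growth), compound 2 and compound 1 lie within the scatter of each other, so neither stands apart. Compound 3 `CCOc1cc(NC(=O)CCCCCCC(=O)Nc2cc(-c3ccc(C)s3)ccc2N)cc2c1OCC([N+](=O)[O-])=C2` differs from compound 2 by 5-methylthiophen-2-yl in place of hydrogen on an aromatic carbon. For the measured compounds named here, one measured step bears on this carbon, hydrogen in place of phenyl, and it is small: a 1.2-fold lower number from compound 1 to compound 2 (0.09 log units; within the scatter). Going by the values given here, with only that step as a guide, no change beyond the scatter is expected. The expected step is a 1.1-fold higher number from compound 2 to compound 3 (0.04 log units; within the scatter). For compound 3 the estimated value is 9500 nM, with an expected range from 4500 nM to 20000 nM.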

Compound 3, concentration for 50% growth inhibition: 6360 nM
Compound 3: middle estimate off by 1.5-fold (0.17 log units), on the high side, and the stated range covers the measured number.
By their numbers in this assay, from the lowest: compounds 3, 2 and 1 (each within the scatter of the next).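

On the aromatic carbon para to an amino group, 5-methylthiophen-2-yl gives a 1.4-fold lower number from compound 2 to compound 3 (0.13 log units; within the scatter) and, against phenyl, a 1.7-fold lower number from compound 1 to compound 3 (0.23 log units; within the scatter) in this assay. A five-membered aromatic ring with a sulfur atom therefore joins phenyl and hydrogen as a third group on this carbon, and none of the three stands apart from the others. Nothing available explains these values.

Open, on these data alone, is whether an amine or a carboxylic acid on this carbon would give a step beyond the scatter. As far as these compounds go, a longer chain between the two amides is equally open.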